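Swapping Chloro for Fluoro on a Benzylsulfanyl Arm

The source may report more compounds than this note shows. Statements on the series, on what has been measured and on what is new or still open speak of the compounds shown alone.

Four compounds share the same kind of arrangement: a central ring carrying an amide and a benzylsulfanyl arm, with the substituent at the end of that arm being either chloro or fluoro. Compound 1 `COc1ccc(C2N=C(SCc3ccc(Cl)cc3)NC(C)=C2C(=O)Nc2ccc(F)cc2)cc1OC` and compound 2 `COc1ccc(C2N=C(SCc3ccc(F)cc3)NC(C)=C2C(=O)Nc2ccc(F)cc2)cc1OC` differ only there, as does the pair compound 3 `CC1=C(C(=O)Nc2ccc(Br)cc2)C(c2ccc(Cl)cc2Cl)N=C(SCc2ccc(Cl)cc2)N1` and compound 4 `CC1=C(C(=O)Nc2ccc(Br)cc2)C(c2ccc(Cl)cc2Cl)N=C(SCc2ccc(F)cc2)N1`. How the core of compound 1 differs from the core of compound 3 is not broken down here.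

In a functional assay on the whole organism (artery, strain albino) with Rattus norvegicus as the target, with a stated time of 240 min, at a dose of 10 mg/kg by the oral route (a higher number here means more inhibition at the dose given (going by the name of the read-out), a lower number less inhibition), compound 1 gives 24.1%, and compound 2 gives 28.7%. The change between them is fluoro in place of chloro on an aromatic carbon, and it made a number 4.6 percentage points higher from compound 1 to compound 2 (within the scatter). Compound 3 gives 32.3% in this assay; its number and those of compounds 1 and 2 all sit within the usual scatter of each other, so the inhibition in this assay is level across the three and no order can be read among them.

Compound 4 has not yet been measured. It differs from compound 3 by fluoro in place of chloro on an aromatic carbon, which is the same change, at the same place, as that from compound 1 to compound 2. Since that earlier step stayed within the scatter, the step from compound 3 to compound 4 is expected to be small as well, about a number 2.7 percentage points higher from compound 3 to compound 4 (within the scatter) in this assay. Compound 4 is therefore estimated to give about 35% in this assay, most likely between 22% and 48%, with the measured number still to come.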

Compound 4, a percentage reported as inhibition, in the whole organism at one dose (the size of the read-out at that dose, not a potency): 36.4%
For compound 4 the middle estimate is 1.4 percentage points below the measured one; the measured number falls inside the stated range.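

Putting fluoro in place of chloro at the end of the benzylsulfanyl arm made a number 4.1 percentage points higher from compound 3 to compound 4 (within the scatter) in this assay. Set beside the step on the other core, this swap reads the same on both cores, so in this small set the result carried over from one core to the other: the same change on two cores in this assay, a number 4.6 percentage points higher (within the scatter) from compound 1 to compound 2 and a number 4.1 percentage points higher (within the scatter) from compound 3 to compound 4, 0.5 percentage points apart, within the scatter of two such steps What this does not show is that fluoro truly gives more inhibition than chloro, since each step on its own cannot be told apart from no change, so the agreement is between two small steps, on only two cores, in a single assay at a single dose, and it says nothing about a swap with a large effect.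

The compounds shown carry only chloro or fluoro at the end of the arm, so what a plain hydrogen, a methoxy group, an amine or a carboxylic acid in that same place would do to the inhibition remains open. Also open, as far as these compounds go, is whether the chloro-to-fluoro swap would read the same on a third core, or at another dose or time.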